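Replacing bromo with pentyl in a small antiproliferative series

The source may report more compounds than this note shows. Statements on the series, on what has been measured and on what is new or still open speak of the compounds shown alone.

In a functional assay on M21 cells (Homo sapiens) for antiproliferative activity, read by sulforhodamine B assay, with a stated time of 48 h (on this read-out lower numbers stand for stronger inhibition and higher numbers for weaker inhibition), compound 1 (`O=C1NCCN1c1ccc(S(=O)(=O)Nc2ccc(I)cc2)cc1`) with iodo gives 260 nM and compound 2 (`O=C1NCCN1c1ccc(S(=O)(=O)Nc2ccc(OC(F)F)cc2)cc1`) with difluoromethoxy gives 410 nM on the same core. Compound 3 (`O=C1NCCN1c1ccc(S(=O)(=O)Nc2ccc(Br)cc2)cc1`) with bromo gives 130 nM in the same test. It stands within the scatter of compound 1 (a 2.0-fold lower number from compound 1 to compound 3 (0.30 log units; within the scatter)) but clear of compound 2 (a 3.2-fold lower number from compound 2 to compound 3 (0.50 log units; beyond the scatter)). The remaining pair differs only within the scatter (a 1.6-fold higher number from compound 1 to compound 2 (0.20 log units; within the scatter)).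

Compound 4 (`CCCCCc1ccc(NS(=O)(=O)c2ccc(N3CCNC3=O)cc2)cc1`) is the next case, with pentyl in place of bromo on an aromatic carbon para to a large group. All three measured steps exchange groups at this same place, and none goes beyond modest in size. Going by the values given here, no measured compound carries a chain like pentyl, so these steps offer only a rough guide. Among the compounds with values here, neither compound 1 nor compound 2 gives a clearly lower number than compound 3, and the one step beyond the scatter (a 3.2-fold lower number from compound 2 to compound 3 (0.50 log units; beyond the scatter)) favours bromo. A modest move towards a higher number, and so weaker inhibition, is therefore expected (a 3.1-fold higher number from compound 3 to compound 4 (0.49 log units; beyond the scatter)) in this assay on this limited evidence. For compound 4 the estimated value is 400 nM with an expected range from 130 nM to 1200 nM in this test.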

Compound 4, half-maximal inhibitory concentration: 870 nM
Estimate against measurement, compound 4: 2.2-fold (0.34 log units) below; low and high end bracket the measured number.
By their numbers in this assay, from the lowest: compounds 3, 1 and 2 (each within the scatter of the next, the first and the last beyond it); then compound 4.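

Going by these compounds alone, at this place, on an aromatic carbon para to a large group, pentyl is the first group whose steps to all the others lie beyond the scatter in this assay: a 6.7-fold higher number from compound 3 to compound 4 (0.83 log units; beyond the scatter), a 3.3-fold higher number from compound 1 to compound 4 (0.52 log units; beyond the scatter) and a 2.1-fold higher number from compound 2 to compound 4 (0.33 log units; beyond the scatter). Among the earlier compounds only the exchange of difluoromethoxy for bromo passed the scatter, whereas compound 4 now sets the weak end of the series, so this place does not accept every group equally and a pentyl chain of 5 heavy atoms in place of bromo costs more inhibition than any exchange among the smaller groups. The information at hand offers nothing that would explain this loss.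

The compounds shown leave open whether the number rises steadily with chain length or whether pentyl is a special case, a question that a shorter chain such as propyl and a longer chain such as heptyl at the same place would settle. They also leave open whether any group here, an amine or a carboxylic acid for instance, could give a lower number than compound 3 does.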